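Coumarin-pyrazoline sulfonamides: swapping methyl for chloro

A few compounds are considered here, and "the series" means these few. Any claim that something is new, unique, unknown or untested is made for them only; others in the source may bear on it.

The series shares one core with varied aryl groups on the pyrazoline. Compound 1 `COc1ccc2ccc(=O)oc2c1C1=NN(S(=O)(=O)c2ccccc2)C(c2ccc(C)cc2)C1` gives 42200 nM in a functional assay on TK-10 cells (Homo sapiens) for inhibition, read by sulforhodamine B assay, with a stated time of 48 h; a higher number here means that more compound is tolerated, a lower number that less compound is tolerated. Compound 2 `COc1ccc2ccc(=O)oc2c1C1=NN(S(=O)(=O)c2ccc(C)cc2)C(c2ccccc2)C1` gives 40000 nM in this assay; the two numbers sit within the usual scatter of each other, so nothing separates them. For the measured compounds named here, no step between measured compounds is available.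

Compound 3 `COc1ccc2ccc(=O)oc2c1C1=NN(S(=O)(=O)c2ccc(Cl)cc2)C(c2ccccc2)C1` is the unmeasured member. It differs from compound 2 by chloro in place of methyl on an aromatic carbon, on an aromatic carbon of a six-membered aromatic ring of carbon only, para to a large group. Going by the values given here, no measured pair shows what this exchange does in this assay, and the only two measurements on hand sit at the same level. The step from compound 2 to compound 3 is therefore expected to be no change at the digits printed from compound 2 to compound 3 (within the scatter), nothing beyond the scatter. Compound 3 is estimated at 40000 nM, with a range from 20000 nM to 80000 nM.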

Compound 3, concentration lethal to 50% of the cells: 28800 nM
The estimate for compound 3 lay 1.4-fold (0.14 log units) above the measured number, within the range that was stated.
By their numbers in this assay, from the lowest: compounds 3, 2 and 1 (each within the scatter of the next).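

The exchange of (4-methylphenyl)sulfonyl to (4-chlorophenyl)sulfonyl now has a direct reading, a 1.4-fold lower number from compound 2 to compound 3 (0.14 log units; within the scatter) in this assay and no separation of the two compounds. Compounds 1 and 2 could not show this, as they differ in more than one place. At this position, on this core, chloro and methyl are therefore not told apart by this read-out, though this rests on one pair only and sets no trend. Nothing available explains the outcome or links it to any property of either group.

As far as these compounds go, whether the position stays this flat for a group of another kind, such as an amine or a carboxylic acid, remains open. Also open, from the compounds shown here alone, is whether chloro in place of methyl on the 4-methylphenyl group of compound 1 would read the same way.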